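Aryl-pyrazole growth inhibitors: halophenyl swap on ring nitrogen

The source may hold more compounds than are shown below. What is called first, only, known or untested is meant among the compounds shown, and "the series" means these compounds.

Measured so far:
Compound 1, `Cc1ccc(-c2cc(/N=C/N(C)C)n(-c3cccc(Cl)c3)n2)cc1`, in a functional assay on NPC-TW01 cells (Homo sapiens) for inhibition, read by MTT assay, with a stated time of 72 h (a higher number here means a weaker inhibitor of growth, a lower number a stronger inhibitor of growth), gives > 100000 nM, a limit of the assay.
Compound 2, `Cc1ccc(-c2cc(/N=C/N(C)C)n(-c3ccc(Br)cc3)n2)cc1`, in this assay gives > 100000 nM, also a limit.
Compound 3, `Cc1ccc(-c2nn(-c3cccc(Cl)c3)c(N)c2C=O)cc1`, in this assay gives > 100000 nM, again a limit.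

The difference between the core of compound 1 and the core of compound 3 is not broken down here. Within the core of compound 1, the change 4-bromophenyl in place of 3-chlorophenyl on an aromatic nitrogen produced a step that the two limits leave unreadable from compound 1 to compound 2. Compound 4, `Cc1ccc(-c2nn(-c3ccc(Br)cc3)c(N)c2C=O)cc1`, carries the same kind of change, (4-bromophenyl in place of 3-chlorophenyl on an aromatic nitrogen), but the surroundings differ: here the ring nitrogen stands next to the ring atom that bears an amino group and two ring bonds from the ring atom that bears a formyl group, whereas in compound 1 it stands next to the ring atom that bears a group of 5 heavy atoms. Since all three values sit at the limit of > 100000 nM in this assay, at which 3 of the 3 values shown sit, compound 4 is expected to show a step that the limit leaves unreadable from compound 3 to compound 4, most likely another limit. The estimate for compound 4 in this assay is 150000 nM.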

Compound 4, concentration for 50% growth inhibition: 28200 nM
Compound 4: middle estimate off by 5.3-fold (0.73 log units), on the high side; measured number below the stated range.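

In this assay, the change to 4-bromophenyl from 3-chlorophenyl on the aromatic nitrogen gives an at least 3.5-fold lower number from compound 3 to compound 4 (0.54 log units; beyond the scatter), so with the amino and formyl groups in the shared core, the change is linked to a lower number beyond the scatter. From the compounds shown here alone, the true size of this step stays open, as the value of compound 3 is a limit. The same change in the core of compound 1 cannot be read, so the result neither shows nor rules out that the change carries from one core to the other, because both values there are limits: the limit of > 100000 nM in this assay, at which 3 of the 4 values shown sit.

The halogen and its ring place change together in these compounds, leaving open which one goes with the step; 4-chlorophenyl or 3-bromophenyl would separate them. Also open, going by these compounds, is how a carboxylic acid or a nitrile in place of the formyl group would read.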